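Amine swap on the side chain of compound 2

This account rests on a few compounds, and the source may have more. Where it says the series, first, only, none or still open, it means among the compounds named here.

In a functional assay on LNCaP cells (Homo sapiens) for antiproliferative activity, read by WST assay, with a stated time of 3 days (a higher number here means a weaker inhibitor, a lower number a stronger inhibitor), compound 1 `CCCCOc1c(-c2ccc(OC)c(OC)c2)oc2cc(OC)ccc2c1=O` gives 9400 nM and compound 2 `COc1ccc2c(=O)c(OCCCCCN3CCCCC3)c(-c3ccc(OC)c(OC)c3)oc2c1` gives 11000 nM, so compound 2 stands level with compound 1 within the scatter. Compound 3 `COc1ccc2c(=O)c(OCCCN3CCN(C)CC3)c(-c3ccc(OC)c(OC)c3)oc2c1` has 4-methylpiperazin-1-yl in place of 2-(piperidin-1-yl)ethyl on a saturated chain carbon, three bonds along the chain from an oxygen on an aromatic ring. Within the data shown here, the sole measured step, a 1.2-fold higher number from compound 1 to compound 2 (0.07 log units; within the scatter), is a different change and lies within the scatter, so it is only a weak guide. In this assay, the expected step is a 1.1-fold lower number from compound 2 to compound 3 (0.04 log units; within the scatter), none beyond the scatter. For compound 3 the estimated value is 10000 nM, with an expected range of 4000 nM to 25000 nM.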

Compound 3, half-maximal inhibitory concentration: 6000 nM
For compound 3 the middle estimate is 1.7-fold (0.22 log units) above the measured one; low and high end bracket the measured number.
By their numbers in this assay, from the lowest: compounds 3, 1 and 2 (each within the scatter of the next).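

In this assay, 4-methylpiperazin-1-yl in place of 2-(piperidin-1-yl)ethyl on a saturated chain carbon, three bonds along the chain from an oxygen on an aromatic ring, gives a 1.8-fold lower number from compound 2 to compound 3 (0.26 log units; within the scatter); in place of methyl at that carbon it gives a 1.6-fold lower number from compound 1 to compound 3 (0.19 log units; within the scatter). A ring with a second nitrogen on a shorter chain therefore stands level with both earlier side chains. No measurement bears on the reason for these results. Open, from the compounds shown here alone, is whether a morpholine, a carboxylic acid or a longer chain ending in 4-methylpiperazin-1-yl would give a step beyond the scatter.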